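Ethyl to methyl: working notes on compound 3

The compounds below may be only part of what the source reports. "The series", "measured", "known", "first", "only" and "open" are said of these compounds alone.

Of the compounds shown here, two have been measured so far in a physicochemical assay for solubility, using the shake flask method, measured as kinetic solubility, with a stated time of 2 h, at pH 7.4; a lower number here means a less soluble compound, a higher number a more soluble compound. Compound 1 `O=C(Nc1ccccc1)c1cc(NCc2ccccc2)ncn1` gives < 5000 nM, which is a limit of the assay and not a number. Going by the values given here, compound 2 `CCN(Cc1ccc(Cl)cc1)c1cc(C(=O)Nc2ccccc2)ncn1` gives 5000 nM, the only true number, so it has no numerical neighbour to be ranked against.

Compound 3 `CN(Cc1ccc(Cl)cc1)c1cc(C(=O)Nc2ccccc2)ncn1` differs from compound 2 by hydrogen in place of methyl on a saturated chain carbon bound to a nitrogen on an aromatic ring, which reads as ethyl to methyl. Among the compounds with values here, no measured pair yet shows this change, and the only anchor is compound 2 at 5000 nM. The expected step of a 1.3-fold lower number from compound 2 to compound 3 (0.10 log units; within the scatter) in this assay is none beyond the scatter, and a report as a limit would not be surprising. For compound 3 the estimated value is 4000 nM, with an expected range of 2000 nM to 8000 nM.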

Compound 3, solubility: < 5000 nM
Compound 3: a limit, no number (the forecaster's own chance of this, stated with the estimate: 55%); the middle value lies beyond the limit too.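

In this assay, ethyl to methyl on a saturated chain carbon bound to a nitrogen on an aromatic ring gives a number no higher from compound 2 to compound 3 (the limit leaves the size open). Compound 3 gives < 5000 nM, which is a limit of the assay and not a number. This is the first reading of any change at this position; it shows only the direction allowed by the limit and adds no second number to the series, so the readings stay gathered at one boundary: the limit of < 5000 nM in this assay, at which 2 of the 3 values shown sit.

The size of this step remains unknown, and the compounds shown give no number to set against compound 2. Also open, going by these compounds, is whether a longer chain such as propyl, or an amine or a carboxylic acid carried on that chain, would give a number clear of the limit in this assay.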